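This account rests on a few compounds, and the source may have more. Where it says the series, first, only, none or still open, it means among the compounds named here.

Working notes on the series. In a functional assay on A2780 cells (Homo sapiens) for antiproliferative activity, read by MTT assay, with a stated time of 48 h (a lower number here means a stronger inhibitor, a higher number a weaker inhibitor), compound 1 (`COc1ccc(-c2cc3c(cn2)[nH]c(=O)n3-c2cc(OC)c(OC)c(OC)c2)cc1`) gives 930 nM, compound 2 (`CCOc1ccc(-c2cc3c(cn2)[nH]c(=O)n3-c2cc(OC)c(OC)c(OC)c2)cc1F`) gives 4330 nM and compound 3 (`COc1ccc(-c2cc3c(cn2)[nH]c(=O)n3-c2cc(OC)c(OC)c(OC)c2)cc1N`) gives 640 nM. Compound 3 stands level with compound 1, since a 1.5-fold lower number from compound 1 to compound 3 (0.16 log units; within the scatter) lies within the scatter, and clear of compound 2, since a 6.8-fold lower number from compound 2 to compound 3 (0.83 log units; beyond the scatter) lies beyond it.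

Compound 4 (`COc1ccc(-c2cc3c(cn2)[nH]c(=O)n3-c2cc(OC)c(OC)c(OC)c2)cc1C(=O)O`) carries carboxy in place of amino on an aromatic carbon, ortho to a methoxy group: carboxy in place of amino on an aromatic carbon. For the measured compounds named here, no measured compound holds a carboxy group, so the evidence is indirect. Going by the values given here, the amino step, a 1.5-fold lower number from compound 1 to compound 3 (0.16 log units; within the scatter), shows only that a group at this carbon can leave the number unchanged within the scatter. The step of a 4.7-fold higher number from compound 1 to compound 2 (0.67 log units; beyond the scatter) shows that a change on this aromatic ring can raise the number modestly. A modest rise in this assay is therefore expected, as a 3.9-fold higher number from compound 3 to compound 4 (0.59 log units; beyond the scatter), though this is an estimate with wide uncertainty. For compound 4 the estimated value is 2500 nM, with an expected range of 700 nM to 10000 nM.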

Compound 4, half-maximal inhibitory concentration: 4120 nM
Compound 4: middle estimate off by 1.6-fold (0.22 log units), on the low side; measured number inside the range.
By their numbers in this assay, from the lowest: compounds 3 and 1 (each within the scatter of the next); then compounds 4 and 2 (each within the scatter of the next).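

In this assay, the carbon ortho to a methoxy group does not treat all groups alike. Amino left the number within the scatter of hydrogen, whereas carboxy moves it beyond the scatter, both against amino (a 6.4-fold higher number from compound 3 to compound 4 (0.81 log units; beyond the scatter)) and against hydrogen (a 4.4-fold higher number from compound 1 to compound 4 (0.65 log units; beyond the scatter)). This single change at one carbon ends level with the 4-ethoxy-3-fluorophenyl compound (a 1.1-fold lower number from compound 2 to compound 4 (0.02 log units; within the scatter)), so two different changes on this ring give numbers within the scatter of each other. Nothing at hand explains why carboxy and amino part here.

Still open, as far as these compounds go, is whether the rise follows the carboxy group as such or any carbonyl-bearing group at this carbon, a question that a methyl ester or a primary amide would address. Also open, from the compounds shown here alone, is how a methylamino or acetamido group would compare with amino at this carbon.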